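A few compounds are considered here, and "the series" means these few. Any claim that something is new, unique, unknown or untested is made for them only; others in the source may bear on it.

Working notes on the series.

Compound 1 `CCC(=O)Nc1ccc(-c2nc3cc(C(F)(F)F)ccc3n2C2CCCCC2)cc1` and compound 2 `CC(=O)Nc1ccc(-c2nc3cc(C(F)(F)F)ccc3n2C2CCCCC2)cc1` share one core and differ only in the chain on the amide. In an ADME assay on BHK cells (Mesocricetus auratus) for cytotoxicity, read by MTT assay, with a stated time of 96 h (a higher number here means that more compound is tolerated, a lower number that less compound is tolerated), compound 1 gives 15000 nM, and in this assay compound 2 gives 15000 nM. The step of no change at the digits printed from compound 1 to compound 2 (within the scatter) shows that shortening the acyl chain by one carbon leaves the read-out unchanged within the scatter, so compound 2 stands level with compound 1 in this assay.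

Compound 3 `Nc1ccc(-c2nc3cc(C(F)(F)F)ccc3n2C2CCCCC2)cc1` is the next point: relative to compound 2 the change is hydrogen in place of acetyl on a nitrogen on an aromatic ring. Within the data shown here, the only step measured so far, shortening of the acyl chain, bears on it indirectly and was flat; no measured step removes the acetyl altogether, so the data give no direction for that cut. Absent any observed effect of the amide chain, the expected step of no change at the digits printed from compound 2 to compound 3 (within the scatter) is none beyond the scatter, with a wider range to allow for the unmeasured loss of the carbonyl. Compound 3 is therefore estimated at 15000 nM, within 5000 nM to 45000 nM.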

Compound 3, half-maximal cytotoxic concentration: > 100000 nM
Compound 3 ended at the assay's limit; the forecaster's own chance of this, stated with the estimate: 20%; middle value at least 6.6-fold (0.82 log units) away from the limit.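

In this assay, taking the acetyl off the nitrogen on the aromatic ring gives an at least 6.6-fold higher number from compound 2 to compound 3 (0.82 log units; beyond the scatter), and taking the propanoyl off gives an at least 6.6-fold higher number from compound 1 to compound 3 (0.82 log units; beyond the scatter), whereas the change in the acyl chain alone gave no change at the digits printed from compound 1 to compound 2 (within the scatter). In this assay compound 3 gives > 100000 nM, which is a limit of the assay and not a number. Across these three compounds the read-out therefore follows the presence or absence of the acyl group on this nitrogen, not the length of its chain, and the full size of both steps stays unfixed because the read-out ends at that limit: the limit of > 100000 nM in this assay, at which 1 of the 3 values shown sits.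

On these data alone, how much of the step belongs to the loss of the carbonyl and how much to the free amino group stays open, and an N-methyl amine or a methanesulfonamide on the same nitrogen would separate the two. As far as these compounds go, whether the flat response to chain length holds beyond acetyl and propanoyl also stays open, and a longer chain such as butanoyl or a ring-bearing acyl group such as benzoyl would test it.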